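Benzyloxy for phenyl on the carbonyl: permeability outlook

The source may hold more compounds than are shown below. What is called first, only, known or untested is meant among the compounds shown, and "the series" means these compounds.

Measured so far in an ADME assay on Caco-2 cells (Homo sapiens) for permeability, in the apical to basolateral direction; a lower number here means that the compound crosses the layer more slowly, a higher number that the compound crosses the layer faster:
compound 1, `CCNC(=O)N1CCC(CN(C2Cc3cc(C#N)ccc3N(Cc3cncn3C)C2)S(=O)(=O)c2ccccn2)CC1`: 0.6 10^-6 cm/s
compound 2, `Cn1cncc1CN1CC(N(CC2CCN(C(=O)N3CCCC3)CC2)S(=O)(=O)c2ccccn2)Cc2cc(C#N)ccc21`: 0.6 10^-6 cm/s
compound 3, `Cn1cncc1CN1CC(N(CC2CCN(C(=O)c3ccccc3)CC2)S(=O)(=O)c2ccccn2)Cc2cc(C#N)ccc21`: 0.5 10^-6 cm/s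

Compound 3 carries the smallest of the three numbers, yet a 1.2-fold lower number from compound 1 to compound 3 (0.08 log units; within the scatter) and a 1.2-fold lower number from compound 2 to compound 3 (0.08 log units; within the scatter) both lie within the scatter, so the three compounds sit together. Compound 4, `Cn1cncc1CN1CC(N(CC2CCN(C(=O)OCc3ccccc3)CC2)S(=O)(=O)c2ccccn2)Cc2cc(C#N)ccc21`, differs from compound 3 by benzyloxy in place of phenyl on a carbonyl carbon. The measured steps that bear on this all exchange the group on the same carbonyl carbon: no change at the digits printed from compound 1 to compound 2 (within the scatter), a 1.2-fold lower number from compound 1 to compound 3 (0.08 log units; within the scatter) and a 1.2-fold lower number from compound 2 to compound 3 (0.08 log units; within the scatter), none of them beyond the scatter. Within the data shown here, no measured step introduces a benzyloxy there, so the expectation rests on these three exchanges alone. Accordingly no change at the digits printed from compound 3 to compound 4 (within the scatter) is expected to stay within the scatter. Compound 4 is estimated at 0.5 10^-6 cm/s in this assay, with a range from 0.25 10^-6 cm/s to 1 10^-6 cm/s.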

Compound 4, apparent permeability: 1 10^-6 cm/s
For compound 4 the middle estimate is 2.0-fold (0.30 log units) below the measured one; measured number inside the range.
By their numbers in this assay, from the lowest: compounds 3, 1, 2 and 4 (each within the scatter of the next).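

In this assay the carbonyl carbon on the amide-type nitrogen in a ring also accepts benzyloxy, an oxygen-linked group, with a 2.0-fold higher number from compound 3 to compound 4 (0.30 log units; within the scatter) and a 1.7-fold higher number from compound 2 to compound 4 (0.22 log units; within the scatter) and a 1.7-fold higher number from compound 1 to compound 4 (0.22 log units; within the scatter) all inside the scatter. Ethylamino, pyrrolidin-1-yl, phenyl and benzyloxy at this place therefore still form one group of values, and no exchange there has yet moved the number beyond the scatter. Nothing shown offers an explanation for these numbers.

As far as these compounds go, whether a carboxylic acid, an amine or a longer chain on this carbonyl carbon would separate from the four remains open. From the compounds shown here alone, the shared core is also constant throughout, so the contribution of other positions is untested here.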